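Swapping chloro for nitro on the amide-side phenyl ring

The source may report more compounds than this note shows. Statements on the series, on what has been measured and on what is new or still open speak of the compounds shown alone.

Three compounds of one shared core were measured in a functional assay on MDA-MB-231 cells (Homo sapiens) for inhibition, read by MTT assay, with a stated time of 72 h; a lower number here means a stronger inhibitor, a higher number a weaker inhibitor:

Compound 1 `O=C(CSc1nc(Nc2ccccc2)c2ccccc2n1)Nc1ccccc1Cl`: 24400 nM
Compound 2 `O=C(CSc1nc(Nc2ccccc2)c2ccccc2n1)Nc1cccc([N+](=O)[O-])c1`: 33000 nM
Compound 3 `O=C(CSc1nc(Nc2ccccc2)c2ccccc2n1)Nc1ccc(Cl)cc1`: 17200 nM

Among the compounds with values here, compound 3 gives the lowest of the three numbers, but its gaps to the others are small: a 1.4-fold lower number from compound 1 to compound 3 (0.15 log units; within the scatter) and a 1.9-fold lower number from compound 2 to compound 3 (0.28 log units; within the scatter) both lie within the scatter, so no compound can be called stronger than another. Compound 4 `O=C(CSc1nc(Nc2ccccc2)c2ccccc2n1)Nc1ccc([N+](=O)[O-])cc1` differs from compound 3 by one change: nitro in place of chloro on an aromatic carbon. Within the data shown here, two measured steps bear on this. Going from a nitrophenyl to a chlorophenyl amide, a 1.9-fold lower number from compound 2 to compound 3 (0.28 log units; within the scatter), and moving the chloro group around the ring, a 1.4-fold lower number from compound 1 to compound 3 (0.15 log units; within the scatter), both stayed within the scatter. Nothing here points to a move beyond the scatter in this assay either way, though the nitro compound 2 sits at the high end. For compound 4 the expected number is 22000 nM, with a range from 10000 nM to 50000 nM, which is estimated as a 1.3-fold higher number from compound 3 to compound 4 (0.11 log units; within the scatter).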

Compound 4, half-maximal inhibitory concentration: 16800 nM
Compound 4: the middle estimate sits 1.3-fold (0.12 log units) above what was measured; low and high end bracket the measured number.
By their numbers in this assay, from the lowest: compounds 4, 3, 1 and 2 (each within the scatter of the next).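

In this assay, chloro and nitro cannot be told apart on an aromatic carbon para to a large group: a 1.0-fold lower number from compound 3 to compound 4 (0.01 log units; within the scatter). Within the data shown here, compound 4 also gives the first comparison of two nitro compounds, 4-nitrophenyl in place of 3-nitrophenyl, with a 2.0-fold lower number from compound 2 to compound 4 (0.29 log units; within the scatter), and it adds a step from the 2-chlorophenyl amide, with a 1.5-fold lower number from compound 1 to compound 4 (0.16 log units; within the scatter), so all the changes seen so far on this ring stay within the scatter. No accompanying measurement speaks to why these compounds read so alike.

Going by these compounds, all four compounds carry chloro or nitro on this ring, so the effect of an amine, a carboxylic acid or a longer chain there remains open. The compounds shown also say nothing about changes elsewhere on the shared core.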